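Nitro in Place of Methyl on a Sugar-Linked Oxadiazole

The source may report more compounds than this note shows. Statements on the series, on what has been measured and on what is new or still open speak of the compounds shown alone.

This account follows three measured compounds and one that awaits its number. Compound 1 `C#CCOc1ccc(-c2noc(NC3CCCCC3)n2)cc1` was tested in an ADME assay on RAW264.7 cells (Mus musculus) for cytotoxicity, read by MTT assay, with a stated time of 48 h (a lower number here means that less compound is tolerated, a higher number that more compound is tolerated), and compound 1 gives 38.3 ug/mL. Compound 3 `C#CCN(c1nc(-c2ccc(OC)cc2)no1)C1CCCCC1` shares the oxadiazole-cyclohexylamine motif, and in this assay compound 3 gives 28 ug/mL. Compound 2 `CC(=O)OC[C@H]1O[C@H](OC[C@@H](Cn2cc(CN(c3nc(-c4cccc(C)c4)no3)C3CCCCC3)nn2)OC(C)=O)C=C[C@@H]1OC(C)=O` carries the acetylated sugar linked through a triazole to the same motif, and in this assay compound 2 gives 46.4 ug/mL. Compound 2 stands alongside compound 1 and compound 3: the gaps between its number and theirs are within the usual scatter, so the three cannot be ordered on these data.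

Compound 4 `CC(=O)OC[C@H]1O[C@H](OC[C@@H](Cn2cc(CN(c3nc(-c4cccc([N+](=O)[O-])c4)no3)C3CCCCC3)nn2)OC(C)=O)C=C[C@@H]1OC(C)=O` keeps the whole of compound 2 except for one change on the aryl ring, (nitro in place of methyl on an aromatic carbon). Going by the values given here, no pair of measured compounds in this set differs by this change alone, so the step has no precedent here.

The step is expected to be small, with no direction that would stand out from the scatter, and a 1.2-fold lower number from compound 2 to compound 4 (0.06 log units; within the scatter) is the estimated change in this assay. Compound 4 is therefore expected to give 40 ug/mL, with a range from 20 ug/mL to 80 ug/mL.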

Compound 4, half-maximal cytotoxic concentration: 100 ug/mL
Beside the measured number, compound 4's estimate is 2.5-fold (0.40 log units) below it; the whole stated range lies below it.
By their numbers in this assay, from the lowest: compounds 3, 1 and 2 (each within the scatter of the next); then compound 4.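

Going by these compounds alone, the exchange of 3-methylphenyl for 3-nitrophenyl gives the first step in this set that can be read at a single place: in this assay the change on this aromatic carbon, meta to a large group, produces a 2.2-fold higher number from compound 2 to compound 4 (0.33 log units; beyond the scatter) and so stands outside the scatter, though it remains modest. Within the data shown here, the earlier compounds could not show this, since their numbers all lie within the scatter of one another and none of them forms a one-place pair with another, so this is the first sign that the group carried at this position can move the number, here toward more compound being tolerated. Nothing at hand accounts for the step, as no measurement of any property of either group bears on it.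

With only methyl and nitro seen at this position, the compounds shown leave open whether another group there, such as an amine, a nitrile or a carboxylic acid, would give a step of similar size and direction. They also leave open whether nitro in place of methyl would do the same at another carbon of the ring, or on a compound without the acetylated sugar.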